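The source may report more compounds than this note shows. Statements on the series, on what has been measured and on what is new or still open speak of the compounds shown alone.

Of the compounds shown here, three have been tested in an ADME assay on HEK293 cells (Homo sapiens) for cytotoxicity, read by reporter gene assay and resazurin assay, with a stated time of 48 h; on this read-out lower numbers stand for higher toxicity in this test and higher numbers for lower toxicity in this test. Compound 1 `O=C(Nc1ccccc1)c1cc(Br)cc(Br)c1` gives only a limit of the assay, > 100000 nM. Compound 3 `O=C(Nc1ccccc1)c1cc(Br)cc(Br)c1O` carries one change against compound 1, namely (hydroxy in place of hydrogen on an aromatic carbon), and in this assay compound 3 gives 34000 nM. The step of an at least 2.9-fold lower number from compound 1 to compound 3 (0.46 log units; beyond the scatter) is read against the fact that compound 1 sits at a limit, (the limit of > 100000 nM in this assay, at which 1 of the 3 values shown sits). Compound 2 `O=C(Nc1cccc(Cl)c1)c1cccc(Br)c1` has a different core, and the difference between the two cores is not broken down here. In this assay compound 2 gives 51000 nM, which lies within the scatter of the value of compound 3. Compound 4 `O=C(Nc1cccc(Cl)c1)c1cc(Br)ccc1O` is not yet measured. It differs from compound 2 by hydroxy in place of hydrogen on an aromatic carbon. This is the same kind of change as from compound 1 to compound 3, not the same: in compound 4 the hydroxy enters ortho to a large group and para to a bromo group, whereas in compound 3 it enters ortho to a bromo group, ortho to a group of 9 heavy atoms and para to a bromo group. Compound 2 starts from a measured number rather than a limit, so a smaller move is expected than the earlier one. The expected step is a 2.0-fold lower number from compound 2 to compound 4 (0.31 log units; beyond the scatter). For compound 4 the estimated value in this assay is 25000 nM, with a range from 10000 nM to 60000 nM.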

Compound 4, half-maximal cytotoxic concentration: 15000 nM
Compound 4: the middle estimate sits 1.7-fold (0.22 log units) above what was measured; the range from low to high includes it.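

In this assay, putting hydroxy in place of hydrogen on an aromatic carbon gives a 3.4-fold lower number from compound 2 to compound 4 (0.53 log units; beyond the scatter) on the second core. The number therefore falls on both cores when this change is made, but the size of the fall cannot be compared exactly between them: the same change on two cores in this assay, an at least 2.9-fold lower number (0.46 log units; beyond the scatter) from compound 1 to compound 3 and a 3.4-fold lower number (0.53 log units; beyond the scatter) from compound 2 to compound 4; the limit leaves it open whether they differ. Two cores are only two cases, so this does not show that the change would lower the number on any further core in the series.

The compounds shown leave open whether a methoxy group, an amine or a carboxylic acid in the same place would move the number the same way, and what hydroxy would do elsewhere on the ring. As far as these compounds go, compound 1 and compound 2 also differ in more than one place, so what the difference between the two cores does by itself remains open.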